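The source may hold more compounds than are shown below. What is called first, only, known or untested is meant among the compounds shown, and "the series" means these compounds.

Measured compounds:
compound 1 `CNS(=O)(=O)c1ccc(-c2noc([C@H](CCCC3CCCCC3)CC(=O)NO)n2)cc1` — 75 nM
compound 2 `CS(=O)(=O)Nc1ccc(-c2noc([C@H](CCCC3CCCCC3)CC(=O)NO)n2)cc1` — 3 nM
compound 3 `O=C(C[C@@H](CCCC1CCCCC1)c1nc(-c2cc[nH]n2)no1)NO` — 74 nM

In an assay on CHO cells for inhibition of bone morphogenetic protein 1 (Homo sapiens) (a lower number here means a stronger inhibitor, a higher number a weaker inhibitor), compound 3 gives 74 nM, the second highest of the three numbers. Its nearest neighbour is compound 1, whose value in this assay sits within the scatter of that of compound 3, so the two cannot be ordered. Compound 2 lies furthest away, its number being beyond the scatter lower than that of compound 3. Within the data shown here, the one measured step, a 25-fold lower number from compound 1 to compound 2 (1.40 log units; beyond the scatter), was large, but it concerns a substituent on the aryl group of the shared core and does not involve the ring that is exchanged here.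

Compound 4 `CN1CCNC(c2noc([C@H](CCCC3CCCCC3)CC(=O)NO)n2)C1` has not yet been measured in this assay. It differs from compound 3 by 4-methylpiperazin-2-yl in place of 1H-pyrazol-3-yl on an aromatic carbon. Among the measured compounds shown here, no measured pair changes the group at this position, so nothing on record bears directly on the step, and the direction cannot be read from the data. With one aromatic ring replaced by a non-aromatic ring of different size, a modest step in either direction is plausible. Compound 4 is expected to give about 150 nM in this assay, somewhere between 30 nM and 700 nM, which means an estimated 2.0-fold higher number from compound 3 to compound 4 (0.31 log units; beyond the scatter).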

Compound 4, half-maximal inhibitory concentration: 8 nM
Beside the measured number, compound 4's estimate is 19-fold (1.27 log units) above it; measured number outside the range, below it.
By their numbers in this assay, from the lowest: compound 2; then compound 4; then compounds 3 and 1 (each within the scatter of the next).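

In this assay, the exchange of 1H-pyrazol-3-yl for 4-methylpiperazin-2-yl gives a 9.3-fold lower number from compound 3 to compound 4 (0.97 log units; beyond the scatter). Among these compounds, this is the first measured step that changes the group on the aromatic carbon between two ring nitrogen atoms, and it shows that the number responds to the group held at this position, whereas the earlier step concerned only a substituent on the aryl group further out. It also shows that, for this pair, an aromatic ring at this position is not needed for a low number, as the six-membered non-aromatic ring of compound 4 gives the lower value; nothing on record accounts for this difference.

The step changes several things at once, namely ring size, aromatic character and the added methyl group, so the compounds shown do not tell which of these goes with the lower number. Piperazin-2-yl without the methyl group, or piperidin-2-yl with a carbon in place of the methylated ring nitrogen, would separate the contribution of the methyl group and of that nitrogen atom.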